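The source may report more compounds than this note shows. Statements on the series, on what has been measured and on what is new or still open speak of the compounds shown alone.

Compound 1 `O=C(NCCNS(=O)(=O)c1ccc(-c2ccccc2OCc2cccc(O)c2)s1)Nc1cc(Cl)cc(Cl)c1` gives 2800 nM in a functional assay on HL-60 cells (Homo sapiens) for inhibition, read by CCK-8 assay, with a stated time of 48 h; a higher number here means a weaker inhibitor, a lower number a stronger inhibitor. Compound 2 `O=[N+]([O-])c1cccc(NC(=S)NCCNS(=O)(=O)c2ccc(-c3ccccc3OCc3cccc(O)c3)s2)c1` differs from compound 1 by a group of 12 heavy atoms (7 carbon, 2 nitrogen, 2 oxygen, 1 sulfur; one six-membered aromatic ring of carbon only) in place of a group of 11 heavy atoms (7 carbon, 1 nitrogen, 1 oxygen, 2 chlorine; one six-membered aromatic ring of carbon only), on an amine nitrogen, and in this assay compound 2 gives 11400 nM; the step is a 4.1-fold higher number from compound 1 to compound 2 (0.61 log units; beyond the scatter). Compound 3 `Cc1ccc(-c2ccsc2S(=O)(=O)NCCNC(=O)Nc2cc(Cl)cc(Cl)c2)c(Oc2ccc(O)c(O)c2)c1` stands on another core; how the core of compound 3 differs from the core of compound 1 is not broken down here. In this assay compound 3 gives 3500 nM, which sits within the scatter of compound 1. Compound 4 `Cc1ccc(-c2ccsc2S(=O)(=O)NCCNC(=S)Nc2cccc([N+](=O)[O-])c2)c(Oc2ccc(O)c(O)c2)c1` carries the same change on the core of compound 3: a group of 12 heavy atoms (7 carbon, 2 nitrogen, 2 oxygen, 1 sulfur; one six-membered aromatic ring of carbon only) in place of a group of 11 heavy atoms (7 carbon, 1 nitrogen, 1 oxygen, 2 chlorine; one six-membered aromatic ring of carbon only), on an amine nitrogen, at the same place as in compound 2. The expectation for the new pair rests on the step of a 4.1-fold higher number from compound 1 to compound 2 (0.61 log units; beyond the scatter) seen on the first core. The step is expected to be a 4.0-fold higher number from compound 3 to compound 4 (0.60 log units; beyond the scatter). Compound 4 is expected to give 14000 nM in this assay, with a likely range from 6000 nM to 35000 nM.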

Compound 4, half-maximal inhibitory concentration: 3400 nM
Beside the measured number, compound 4's estimate is 4.1-fold (0.61 log units) above it; measured number outside the range, below it.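

In this assay, replacing the (3,5-dichlorophenyl)carbamoyl group on the amine nitrogen with the group of 12 heavy atoms gives a 1.0-fold lower number from compound 3 to compound 4 (0.01 log units; within the scatter). The same change therefore does not carry over in size from the core of compound 1 to the core of compound 3: the same change on two cores in this assay, a 4.1-fold higher number (0.61 log units; beyond the scatter) from compound 1 to compound 2 and a 1.0-fold lower number (0.01 log units; within the scatter) from compound 3 to compound 4, 4.2-fold (0.62 log units) apart, beyond the scatter of two such steps. These two pairs show that the step differs between these two cores, but they do not show which part of the cores goes with the difference or how the change would read on any further core.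

As far as these compounds go, the sulfur and the nitro group enter together, so it remains open which of them goes with the step on the core of compound 1. Also open, from the compounds shown here alone, is how an amine or a carboxylic acid in place of the nitro group would read on either core.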